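A few compounds are considered here, and "the series" means these few. Any claim that something is new, unique, unknown or untested is made for them only; others in the source may bear on it.

Measured so far in a functional assay on MCF7 cells (Homo sapiens) for cytotoxicity, read by MTT assay, with a stated time of 3 days; on this read-out lower numbers stand for stronger inhibition and higher numbers for weaker inhibition:
compound 1, `Oc1ccc(-c2cccc(O)c2)cc1`: a limit of the assay, > 100 ug/mL
compound 2, `Nc1ccc(-c2cccc(O)c2)cc1`: a limit of the assay, > 100 ug/mL
compound 3, `COc1ccc(-c2cccc(O)c2)c(OC)c1`: 50.2 ug/mL

Among the compounds with values here, compound 3 carries the only number in the set; the other two values sit at the limit of > 100 ug/mL in this assay, at which 2 of the 3 values shown sit. The change from compound 1 to compound 2 is amino in place of hydroxy on an aromatic carbon, and it gives a step that the two limits leave unreadable from compound 1 to compound 2. Compound 4, `COc1ccc(-c2cccc(N)c2)c(OC)c1`, is not yet measured. It differs from compound 3 by amino in place of hydroxy on an aromatic carbon. This is the same kind of change as from compound 1 to compound 2, though the place is not the same: there the group sits para to a group of 7 heavy atoms, here meta to a large group. How the core of compound 3 differs from the core of compound 1 is not broken down here. A small step of a 1.2-fold higher number from compound 3 to compound 4 (0.08 log units; within the scatter) is expected in this assay. This rests on compound 3 at 50.2 ug/mL as the only numeric anchor, the measured step of the same kind giving no readable size. Compound 4 is expected to give 60 ug/mL in this assay, between 25 ug/mL and 150 ug/mL.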

Compound 4, half-maximal inhibitory concentration: > 100 ug/mL
Compound 4: a limit, no number; the forecaster's own chance of this, stated with the estimate: 40%; at least 1.6-fold (0.22 log units) between middle value and limit.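

In this assay, amino in place of hydroxy on the core of compound 3 gives an at least 1.9-fold higher number from compound 3 to compound 4 (0.29 log units; that floor lies within the scatter); compound 4 is a limit of the assay, so this is a floor only, and no change beyond the scatter is established. The same change on the core of compound 1 cannot be read, so the data do not show whether its effect carries from one core to the other, and the group also sits in a different place on the two cores. Most of the series gives no number: the limit of > 100 ug/mL in this assay, at which 3 of the 4 values shown sit.

The compounds shown leave open whether a carboxylic acid or an acetamide in place of the hydroxy of compound 3 would stay measurable. Within the data shown here, no single-place pair isolates what the two methoxy groups of compound 3 contribute.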